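Chloro to Methoxycarbonyl: Expected Shift in Growth Inhibition

The source may hold more compounds than are shown below. What is called first, only, known or untested is meant among the compounds shown, and "the series" means these compounds.

Going by the values given here, in a functional assay on HT-29 cells (Homo sapiens) for antiproliferative activity, read by sulforhodamine B assay, with a stated time of 48 h (on this read-out lower numbers stand for stronger inhibition of growth and higher numbers for weaker inhibition of growth), compound 3 `NS(=O)(=O)NCCC1CCN(c2cc(-c3ccc(Cl)cc3)ncn2)CC1` gives 30500 nM, the highest of the three numbers measured so far. Compound 1 `COC(=O)c1ccc(-c2cc(N3CCC(CNS(N)(=O)=O)CC3)ncn2)cc1` gives 22900 nM, which sits within the scatter of compound 3. Among the compounds with values here, compound 2 `CC(C)(C)c1ccc(-c2cc(N3CCC(CCNS(N)(=O)=O)CC3)ncn2)cc1` gives 10300 nM, and the step of a 3.0-fold higher number from compound 2 to compound 3 (0.47 log units; beyond the scatter) is the only measured change at this position of the aromatic ring. Compound 4 `COC(=O)c1ccc(-c2cc(N3CCC(CCNS(N)(=O)=O)CC3)ncn2)cc1` differs from compound 3 by methoxycarbonyl in place of chloro on an aromatic carbon. Within the data shown here, no measured step covers this exact swap. Compound 1 carries the same methoxycarbonyl group but a shorter chain to the sulfamide, and its number agrees with that of compound 3 within the scatter. Compound 4 is therefore expected to show a 1.4-fold lower number from compound 3 to compound 4 (0.14 log units; within the scatter), nothing beyond the scatter. Compound 4 is estimated at 22000 nM, with a range from 8000 nM to 60000 nM.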

Compound 4, concentration for 50% growth inhibition: 19600 nM
The estimate for compound 4 lay 1.1-fold (0.05 log units) above the measured number, and the stated range covers the measured number.
By their numbers in this assay, from the lowest: compounds 2, 4, 1 and 3 (each within the scatter of the next, the first and the last beyond it).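

In this assay, methoxycarbonyl on this aromatic carbon cannot be told apart from chloro (a 1.6-fold lower number from compound 3 to compound 4 (0.19 log units; within the scatter)) or from tert-butyl (a 1.9-fold higher number from compound 2 to compound 4 (0.28 log units; within the scatter)), even though compounds 2 and 3 themselves differ beyond the scatter. With methoxycarbonyl held fixed, lengthening the chain to the sulfamide also stays within the scatter (a 1.2-fold lower number from compound 1 to compound 4 (0.07 log units; within the scatter)). Nothing available here explains these numbers. Still open, as far as these compounds go, is whether an amine or a carboxylic acid at this position would move the number beyond the scatter. The same question stands for a longer chain to the sulfamide.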